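Growth inhibition notes: from compound 2 to compound 4

The compounds below may be only part of what the source reports. "The series", "measured", "known", "first", "only" and "open" are said of these compounds alone.

In a functional assay on DU-145 cells (Homo sapiens) for inhibition, read by trypan blue exclusion, with a stated time of 96 h (a lower number here means a stronger inhibitor of growth, a higher number a weaker inhibitor of growth), compound 1 (`O=C(/C(=C\c1ccc(O)cc1O)S(=O)(=O)c1ccccc1Br)c1ccc(Br)cc1`) reads > 100000 nM and this is a limit of the assay, not a number. Compound 2 (`O=C(/C(=C\c1ccccc1F)S(=O)(=O)c1ccc(Br)cc1)c1ccc(Cl)cc1`) gives 25000 nM as the higher of the two actual numbers. Its nearest neighbour is compound 3 (`O=C(/C(=C\c1ccccc1OCc1ccccc1)S(=O)(=O)Cc1ccc(Cl)cc1)c1ccc(Br)cc1`) at 10000 nM and the gap between them lies beyond the scatter, with compound 3 the lower.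

Compound 4 (`COc1ccc(/C=C(\C(=O)c2ccc(Cl)cc2)S(=O)(=O)c2ccc(Br)cc2)cc1O`) is not yet measured. It differs from compound 2 at one place, on a double-bonded chain carbon bound to a double-bonded chain carbon, with 3-hydroxy-4-methoxyphenyl in place of 2-fluorophenyl (3-hydroxy-4-methoxyphenyl in place of 2-fluorophenyl on a double-bonded chain carbon bound to a double-bonded chain carbon). Going by the values given here, no measured pair isolates this change, so the expectation is loose. Compound 3 at 10000 nM shows that numbers lower than that of compound 2 occur in the series, although it differs from compound 2 in more than one place. Compound 1 also carries hydroxyl groups and its > 100000 nM is a limit, so a rise cannot be ruled out. The estimated step of a 3.1-fold lower number from compound 2 to compound 4 (0.49 log units; beyond the scatter) points to a lower number in this assay and is expected to lie beyond the scatter, on thin evidence. For compound 4 the estimated value is 8000 nM with an expected range from 800 nM to 50000 nM in this assay as the working figure.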

Compound 4, concentration for 50% growth inhibition: 10000 nM
Compound 4: middle estimate off by 1.3-fold (0.10 log units), on the low side, within the range that was stated.
By their numbers in this assay, from the lowest: compounds 3 and 4 (each within the scatter of the next); then compound 2. At a limit, above all of these: compound 1.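

Going by these compounds alone, exchanging 2-fluorophenyl for 3-hydroxy-4-methoxyphenyl gives a 2.5-fold lower number from compound 2 to compound 4 (0.40 log units; beyond the scatter) in this assay, and this is the first change at a single place that can be read. The step is modest, but it shows that this position accepts a larger group carrying both a hydroxyl and a methoxy group, and that the number falls rather than rises with this replacement. The values shown give no measured basis for assigning a cause to this step.

On these data alone, one replacement removes the fluorine and adds the hydroxyl and the methoxy group together, so the share of each in the step stays open, and 3-hydroxyphenyl and 4-methoxyphenyl at this place would be needed to separate them. As far as these compounds go, it also remains open how a phenyl ring carrying an amine or a carboxylic acid would read at this place, and whether the same replacement gives a step of similar size when the rest of the molecule differs from compound 2.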